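A few compounds are considered here, and "the series" means these few. Any claim that something is new, unique, unknown or untested is made for them only; others in the source may bear on it.

In a functional assay on Jurkat cells (Homo sapiens) for inhibition (a lower number here means a stronger inhibitor, a higher number a weaker inhibitor), compound 2 `CCOC(=O)c1cnc(N(C)N2C(=O)C=C(C)C2=O)nc1-c1cccs1` gives 94 nM and compound 1 `CCOC(=O)c1cnc(N(C)N2C(=O)C=C(C)C2=O)nc1-c1cc2ccccc2s1` gives 130 nM on the same core, so the two stand level within the scatter and neither can be placed ahead of the other. Compound 2 carries thiophen-2-yl where compound 1 carries 1-benzothiophen-2-yl. Compound 3 `CCOC(=O)c1cnc(N(C)N2C(=O)C=C(C)C2=O)nc1-c1ccc(C)s1` has not yet been measured. It differs from compound 2 by methyl in place of hydrogen on an aromatic carbon, a change that reads methyl in place of hydrogen on an aromatic carbon and turns thiophen-2-yl into 5-methylthiophen-2-yl. Among the compounds with values here, only one measured step bears on this group, namely a 1.4-fold lower number from compound 1 to compound 2 (0.14 log units; within the scatter) and it stays small. That step involves no methyl group, so the evidence is indirect and the range must stay wide. In this assay no shift beyond the scatter is expected in either direction, and the estimated change is a 1.1-fold higher number from compound 2 to compound 3 (0.03 log units; within the scatter) with no direction favoured. For compound 3 the expected value is 100 nM within an estimated range from 40 nM to 250 nM once it is measured.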

Compound 3, half-maximal inhibitory concentration: 350 nM
Compound 3: middle estimate off by 3.5-fold (0.54 log units), on the low side; measured number outside the range, above it.
By their numbers in this assay, from the lowest: compounds 2 and 1 (each within the scatter of the next); then compound 3.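

Within this assay, methyl in place of hydrogen on an aromatic carbon gives a 3.7-fold higher number from compound 2 to compound 3 (0.57 log units; beyond the scatter), the first step among these compounds that lies beyond the scatter, so this position, next to the ring sulfur and two ring bonds from the ring atom that bears a large group, responds to a single added carbon. The earlier pair gave no sign of this, as compound 1 and compound 2 stand level within the scatter, whereas replacing 1-benzothiophen-2-yl with 5-methylthiophen-2-yl gives a 2.7-fold higher number from compound 1 to compound 3 (0.43 log units; beyond the scatter), so across these three compounds the number does not follow the count of atoms added to thiophen-2-yl. Nothing available here accounts for the weaker inhibition seen with the methyl group.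

The compounds shown leave open whether the shift is particular to methyl or would also appear with chlorine, a methoxy group or an ethyl chain on this carbon. They also leave open whether methyl on another carbon of the thiophen-2-yl group would shift the number, and whether a carboxylic acid in place of the ethyl ester would change how this step reads.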